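The source may hold more compounds than are shown below. What is called first, only, known or untested is meant among the compounds shown, and "the series" means these compounds.

Compound 1 `COC(=O)c1sc2c(C)cccc2c1Nc1cc(OC)c(OC)c(OC)c1`: 1630 nM
Compound 2 `COC(=O)c1sc2cc(OC)ccc2c1Nc1cc(OC)c(OC)c(OC)c1`: 10.3 nM
Compound 3 `COC(=O)c1sc2cc(C)ccc2c1Nc1cc(OC)c(OC)c(OC)c1`: 0.7 nM

In a functional assay on SEM cells (Homo sapiens) for cytotoxicity, read by MTT assay, with a stated time of 72 h (a higher number here means a weaker inhibitor, a lower number a stronger inhibitor), compound 2 gives 10.3 nM, the second highest of the three numbers, with compound 3 nearest and compound 1 furthest. Compound 4 `CCOC(=O)c1sc2cc(OC)ccc2c1Nc1cc(OC)c(OC)c(OC)c1` differs from compound 2 by methyl in place of hydrogen on a saturated chain carbon bound to an oxygen next to a carbonyl group, which turns methoxycarbonyl into ethoxycarbonyl. Going by the values given here, the only measured single-place step, a 15-fold lower number from compound 2 to compound 3 (1.17 log units; beyond the scatter), is large, but it replaces a methoxy group elsewhere on the shared core, so it bears only indirectly. Among the compounds with values here, no measured step touches the methoxycarbonyl group. A step within the scatter is therefore expected, tilted toward a higher number. The expected change is a 1.7-fold higher number from compound 2 to compound 4 (0.24 log units; within the scatter). Compound 4 is estimated at 18 nM, with an expected range of 4 nM to 90 nM.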

Compound 4, half-maximal inhibitory concentration: 10.2 nM
The estimate for compound 4 lay 1.8-fold (0.25 log units) above the measured number; the measured number falls inside the stated range.
By their numbers in this assay, from the lowest: compound 3; then compounds 4 and 2 (each within the scatter of the next); then compound 1.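

Changing methoxycarbonyl to ethoxycarbonyl gives a 1.0-fold lower number from compound 2 to compound 4 (0.00 log units; within the scatter) in this assay, so this added methyl on the saturated chain carbon leaves the number in place. Going by these compounds alone, the earlier compounds held no step at this group, and the only earlier step, a 15-fold lower number from compound 2 to compound 3 (1.17 log units; beyond the scatter), lies elsewhere on the shared core. Nothing measured here accounts for this flat result. Going by these compounds, whether a longer chain, a carboxylic acid or an amide at this place would also leave the number in place stays open. So does whether ethoxycarbonyl would do the same on the core of compound 3.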